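Removing the Para Chloro: From Compound 2 to Compound 3

A few compounds are considered here, and "the series" means these few. Any claim that something is new, unique, unknown or untested is made for them only; others in the source may bear on it.

Two compounds have so far been measured in a functional assay on the whole organism (strain Swiss) with Mus musculus as the target, in the maximal electroshock model, with a stated time of 1 h, at a dose of 300 mg/kg by the intraperitoneal route; on this read-out higher numbers stand for a stronger effect at the one dose given and lower numbers for a weaker effect:

Compound 1, `CCC(C(=O)N1CCN(c2ccc(C(F)(F)F)cc2)CC1)N1C(=O)CCC1=O`, gives 0%.
Compound 2, `CCC(C(=O)N1CCN(c2ccc(Cl)cc2)CC1)N1C(=O)CCC1=O`, gives 25%.

Among the measured compounds shown here, compound 2 stands highest of the two numbers; its nearest neighbour is compound 1, and the only measured step, a number 25 percentage points higher from compound 1 to compound 2 (beyond the scatter), lies beyond the scatter and is of modest size. Compound 3, `CCC(C(=O)N1CCN(c2ccccc2)CC1)N1C(=O)CCC1=O`, has not yet been measured in this assay. It differs from compound 2 in one place: hydrogen in place of chloro on an aromatic carbon. For the measured compounds named here, no measured step covers this particular change. The step from compound 1 to compound 2 touches the same place on the ring, where one group para to a large group was swapped for another, but it does not tell what happens when that group is removed altogether, so it bears on the question only loosely. Going by the values given here, with no directly comparable step, the expectation for compound 3 is a number near that of compound 2, and the step of a number 5 percentage points lower from compound 2 to compound 3 (within the scatter) is expected to stay within the scatter. Compound 3 is therefore estimated at 20%, with a range from 0% to 50%.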

Compound 3, a percentage reported as activity, at one dose (the size of the read-out at that dose, not a potency): 75%
Compound 3: the middle estimate sits 55 percentage points below what was measured, outside the stated range (above it).
By their numbers in this assay, from the lowest: compound 1; then compound 2; then compound 3.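

In this assay, among the compounds shown here, the place para to a large group on the aromatic ring proves far more sensitive than the single earlier step could show: hydrogen in place of chloro gives a number 50 percentage points higher from compound 2 to compound 3 (beyond the scatter) in the effect, and hydrogen in place of trifluoromethyl gives a number 75 percentage points higher from compound 1 to compound 3 (beyond the scatter) on the same scale. The earlier comparison only set one group against another, whereas these steps show that the unsubstituted phenyl of compound 3 stands clearly highest of the three, and that both groups go with a lower number, trifluoromethyl more so than chloro. Nothing available accounts for this drop on adding either group.

The compounds shown leave open whether any other group at this place, such as fluoro, methyl or methoxy, could keep the effect seen with hydrogen, or whether only hydrogen reaches this level. They also leave open how the effect would respond to a change elsewhere in the shared core, and, with only one dose and one time given, how compound 3 would behave under other conditions.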